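Moving chloro: 2-chlorophenyl to 4-chlorophenyl

The compounds below may be only part of what the source reports. "The series", "measured", "known", "first", "only" and "open" are said of these compounds alone.

In a functional assay on HCT-116 cells (Homo sapiens) for antiproliferative activity, read by MTT assay, with a stated time of 72 h (on this read-out lower numbers stand for stronger inhibition and higher numbers for weaker inhibition), compound 1 `CCCNc1ccnc(Nc2ccc(NC(=O)Nc3ccc(Cl)c(C(F)(F)F)c3)cc2)n1` gives 4240 nM. Compound 3 `O=C(Nc1ccc(Nc2nccc(Nc3ccccc3Cl)n2)cc1)Nc1ccc(Cl)c(C(F)(F)F)c1` gives 8100 nM, within the scatter of compound 1, as a 1.9-fold higher number from compound 1 to compound 3 (0.28 log units; within the scatter) shows. Compound 2 `O=C(Nc1ccc(Nc2nccc(Nc3ccccc3)n2)cc1)Nc1ccc(Cl)c(C(F)(F)F)c1` reads > 50000 nM, which is a limit of the assay.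

Compound 4 `O=C(Nc1ccc(Nc2nccc(Nc3ccc(Cl)cc3)n2)cc1)Nc1ccc(Cl)c(C(F)(F)F)c1` differs from compound 3 by 4-chlorophenyl in place of 2-chlorophenyl on a nitrogen on an aromatic ring. Among the compounds with values here, no measured step moves the chloro. The closest is the at least modest an at least 6.1-fold lower number from compound 2 to compound 3 (0.79 log units; beyond the scatter), which adds chloro to that phenyl. Compound 4 keeps a chloro, so a return to the limit of compound 2 is not the main expectation. The expected change, none beyond the scatter, is estimated as a 1.2-fold higher number from compound 3 to compound 4 (0.09 log units; within the scatter). For compound 4 the estimate is 10000 nM, with an expected range of 3000 nM to 40000 nM.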

Compound 4, half-maximal inhibitory concentration: 4660 nM
The estimate for compound 4 lay 2.1-fold (0.33 log units) above the measured number; measured number inside the range.
By their numbers in this assay, from the lowest: compounds 1, 4 and 3 (each within the scatter of the next). At a limit, above all of these: compound 2.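

In this assay, 2-chlorophenyl and 4-chlorophenyl on this nitrogen are not told apart (a 1.7-fold lower number from compound 3 to compound 4 (0.24 log units; within the scatter)), and 4-chlorophenyl also sits within the scatter of propyl (a 1.1-fold higher number from compound 1 to compound 4 (0.04 log units; within the scatter)). The lower number that chloro gives over plain phenyl therefore holds at both places on that ring, with an at least 10-fold lower number from compound 2 to compound 4 (1.03 log units; beyond the scatter) as the larger reading. The value for compound 2 is a limit, not a number: the limit of > 50000 nM in this assay, at which 1 of the 4 values shown sits.

Open, on these data alone, is how fluoro or methoxy in place of chloro on that phenyl would read. Also open, as far as these compounds go, is whether a longer chain than propyl, or a cyclohexyl, on this nitrogen would stay level with compound 1.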